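Hydroxy Added to Compound 2: What to Expect

The source may report more compounds than this note shows. Statements on the series, on what has been measured and on what is new or still open speak of the compounds shown alone.

Of the compounds shown here, two have been measured in a functional assay on SH-SY5Y cells (Homo sapiens) for cytotoxicity, read by MTT assay, with stated times of 8 h, 30 min and 12 h, tested at 0.5 uM; a higher number here means a stronger effect of the compound at the concentration tested, a lower number a weaker effect. Compound 1 `N=C(NCc1ccc(O)cc1)[C@@H]1CCC(=O)N1Cc1ccccc1[N+](=O)[O-]` gives 26.9%. Compound 2 `Cc1ccc(CN2C(=O)CC[C@H]2C(=N)NCc2ccccc2)cc1` gives 23.5%. These two readings lie within the scatter of each other, so compound 2 stands alongside compound 1 rather than apart from it. Compound 3 `Cc1ccc(CN2C(=O)CC[C@H]2C(=N)NCc2ccc(O)cc2)cc1` has not yet been measured. It differs from compound 2 in one place: hydroxy in place of hydrogen on an aromatic carbon. Among the measured compounds shown here, compound 1 already carries a 4-hydroxybenzyl on the shared core and reads much like compound 2, but the two differ in a second place as well, so no single step between them can be counted. With nothing counted to lean on, the step expected in this assay is a number 1.5 percentage points higher from compound 2 to compound 3 (within the scatter), which is none beyond the scatter. Compound 3 is therefore estimated at 25%, most likely between 14% and 36%.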

Compound 3, a percentage reported as activity, at one concentration (the size of the read-out at that concentration, not a potency): 21.9%
Estimate against measurement, compound 3: 3.1 percentage points above, and the stated range covers the measured number.
By their numbers in this assay, from the lowest: compounds 3, 2 and 1 (each within the scatter of the next).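

In this assay, hydroxy in place of hydrogen on this aromatic ring gives a number 1.6 percentage points lower from compound 2 to compound 3 (within the scatter), so the added group produces no difference that can be told from the scatter. Compound 3 also makes the other side of the shared core readable as a single change, and 4-methylphenyl in place of 2-nitrophenyl gives a number 5 percentage points lower from compound 1 to compound 3 (within the scatter), again no step beyond the scatter. Nothing measured here speaks to what lies behind either step.

An amine or a carboxylic acid in place of the hydroxy on this ring could still give a different reading, and the compounds shown do not tell. These readings also come from one concentration, so they say nothing about how the compounds compare at higher or lower doses.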